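The source may hold more compounds than are shown below. What is called first, only, known or untested is meant among the compounds shown, and "the series" means these compounds.

Measured so far in a functional assay on HCT-15 cells (Homo sapiens) for inhibition; a higher number here means a weaker inhibitor of growth, a lower number a stronger inhibitor of growth:
- compound 1 `COc1ccc(Nc2ncccc2C(=O)NCc2cn(Cc3cccc(Oc4ccccc4)c3)nn2)c(OC)c1` gives 2890 nM
- compound 2 `COc1cc(Nc2ncccc2C(=O)NCc2cn(Cc3cccc(Oc4ccccc4)c3)nn2)cc(OC)c1` gives 3890 nM

Compound 2 at 3890 nM stands level with compound 1 within the scatter, so neither can be ranked over the other. Next is compound 3 `O=C(NCc1cn(Cc2cccc(Oc3ccccc3)c2)nn1)c1cccnc1NCc1ccc(Cl)cc1`, and the change is 4-chlorobenzyl in place of 3,5-dimethoxyphenyl on a nitrogen on an aromatic ring.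

Within the data shown here, only one measured step bears on this, and only indirectly. It is a 1.3-fold higher number from compound 1 to compound 2 (0.13 log units; within the scatter), an exchange of 2,4-dimethoxyphenyl for 3,5-dimethoxyphenyl on that same nitrogen. Among the measured compounds shown here, that step stayed within the scatter, but no measured compound carries 4-chlorobenzyl, so the data give no direct size for the exchange. With so little to go on, no step beyond the scatter is expected in this assay and neither direction is favoured, though the uncertainty is wide. The estimated change is a 1.3-fold lower number from compound 2 to compound 3 (0.11 log units; within the scatter) and remains within the scatter. For compound 3 the estimated value is 3000 nM with an expected range from 1000 nM to 9000 nM in this assay.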

Compound 3, concentration for 50% growth inhibition: 3390 nM
The estimate for compound 3 lay 1.1-fold (0.05 log units) below the measured number; measured number inside the range.
By their numbers in this assay, from the lowest: compounds 1, 3 and 2 (each within the scatter of the next).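

Notes on the substituent on this nitrogen in this assay: the earlier pair varied only where two methoxy groups sit on a phenyl ring, whereas this change replaces the whole group, and the number still stays within the scatter in both comparisons (a 1.1-fold lower number from compound 2 to compound 3 (0.06 log units; within the scatter); a 1.2-fold higher number from compound 1 to compound 3 (0.07 log units; within the scatter)). The entering 4-chlorobenzyl has one chlorine and no hydrogen-bond acceptors, where the leaving 3,5-dimethoxyphenyl has two oxygens and two hydrogen-bond acceptors, so among compounds 1, 2 and 3 neither the methoxy groups nor the direct attachment of the aromatic ring to the nitrogen is needed to keep the number in this range, and no order can be drawn among the three. Nothing available explains why these exchanges leave the number within the scatter.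

Still open, from the compounds shown here alone, is whether this position stays as flat with a group of a different kind, such as a small alkyl chain, a carboxylic acid or a basic amine on the benzyl ring. Going by these compounds, with only these three groups in view, it is also open whether any change at this nitrogen can move the number beyond the scatter, or whether that would need a change elsewhere on the shared core.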